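This account rests on a few compounds, and the source may have more. Where it says the series, first, only, none or still open, it means among the compounds named here.

Compound 2 `Cc1cc(Cl)ccc1OCc1nnc(-c2cccc(F)c2)o1` is the starting point of this step. In an ADME assay on cells for inhibition of anoctamin-2 (Homo sapiens), read by fluorescence, with a stated time of 20 min (on this read-out lower numbers stand for stronger inhibition and higher numbers for weaker inhibition), compound 2 gives > 100000 nM, which is a limit of the assay and not a number. Compound 1 `Cc1cc(Cl)ccc1OCc1nnc(-c2ccccc2F)o1` is one of two measured neighbours, and in this assay compound 1 gives > 100000 nM, again a limit. Compound 3 `Cc1cc(Cl)ccc1OCc1nnc(-c2ccco2)o1` is the other neighbour, and in this assay compound 3 gives > 100000 nM, also a limit. All three values sit at the limit of > 100000 nM in this assay, at which 3 of the 3 values shown sit, so the steps a step that the two limits leave unreadable from compound 1 to compound 2, a step that the two limits leave unreadable from compound 1 to compound 3 and a step that the two limits leave unreadable from compound 2 to compound 3 cannot be read in size or direction. Compound 4 `COc1cccc(-c2nnc(COc3ccc(Cl)cc3C)o2)c1` differs from compound 2 by methoxy in place of fluoro on an aromatic carbon. The measured steps bear on this change only in that none of the three variants of the aromatic group reached a readable inhibition, so no step beyond the scatter can be expected in this assay, and a further limit is the most likely outcome. Compound 4 is therefore estimated at 100000 nM, with a range from 30000 nM to 300000 nM, which amounts to an expected step of a number no higher from compound 2 to compound 4 (the limit leaves the size open).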

Compound 4, half-maximal inhibitory concentration: > 100000 nM
Compound 4 was reported as a limit; the forecaster's own chance of this, stated with the estimate: 80%; the middle value sits exactly at the limit.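

In this assay compound 4 gives > 100000 nM, which is a limit of the assay. For the compounds shown here, no new step can therefore be read from compound 2 to compound 4: the limit of > 100000 nM in this assay, at which 4 of the 4 values shown sit. The compounds shown leave open which change, if any, would bring a readable inhibition.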